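The compounds below may be only part of what the source reports. "The series", "measured", "known", "first", "only" and "open" are said of these compounds alone.

Three measured compounds share one sulfonyl-bearing core and differ in the group carried on the amine side. Compound 1 `O=S(=O)(NCCNCc1cccc2ccccc12)c1cc(C(F)(F)F)cc(C(F)(F)F)c1` gives 22000 nM in a functional assay on ASPC1 cells (Homo sapiens) for inhibition, read by MTT assay, with a stated time of 72 h (on this read-out lower numbers stand for stronger inhibition of growth and higher numbers for weaker inhibition of growth), compound 2 `O=S(=O)(NCCNCc1ccc(-c2ccccc2)cc1)c1cc(C(F)(F)F)cc(C(F)(F)F)c1` gives 2800 nM, and compound 3 `O=S(=O)(NCCCNCC1COc2ccccc2O1)c1cc(C(F)(F)F)cc(C(F)(F)F)c1` gives 2900 nM. Among these three numbers compound 3 stands second highest: its value and that of compound 2 lie within the scatter of each other, so nothing separates them, while compound 1 sits beyond the scatter above compound 3.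

Compound 4 `COc1ccccc1CNCCCNS(=O)(=O)c1cc(C(F)(F)F)cc(C(F)(F)F)c1` has not yet been measured. It differs from compound 3 in one place: 2-methoxyphenyl in place of 2,3-dihydro-1,4-benzodioxin-2-yl on a saturated chain carbon bound to an amine nitrogen. Going by the values given here, no measured pair in this set shows a change of this kind, so there is no step on which to lean, and the expectation rests on the similar values of compound 2 and compound 3.

Compound 4 is therefore expected to stay close to compound 3, with an estimated step of a 1.2-fold higher number from compound 3 to compound 4 (0.08 log units; within the scatter) that need not exceed the scatter. For compound 4 the estimate is 3500 nM, within a range of 1200 nM to 10000 nM.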

Compound 4, concentration for 50% growth inhibition: 4600 nM
Estimate against measurement, compound 4: 1.3-fold (0.12 log units) below, and the stated range covers the measured number.
By their numbers in this assay, from the lowest: compounds 2, 3 and 4 (each within the scatter of the next); then compound 1.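

Read in this assay, the change to 2-methoxyphenyl on a saturated chain carbon bound to an amine nitrogen gives a 1.6-fold higher number from compound 3 to compound 4 (0.20 log units; within the scatter), the first step seen at this place. The six-membered non-aromatic ring of 2,3-dihydro-1,4-benzodioxin-2-yl can therefore give way to an aromatic ring with a single methoxy group without the two compounds separating in this assay. Nothing measured here explains this result.

From the compounds shown here alone, whether a different kind of group at this place, such as a carboxylic acid or a pyridine ring, would move the number beyond the scatter remains open. Going by these compounds, the effect of a longer chain also remains open, since compound 3 and compound 4 share one chain and compounds 1 and 2 each differ from them in more than one place.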